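The source may report more compounds than this note shows. Statements on the series, on what has been measured and on what is new or still open speak of the compounds shown alone.

Measured so far in a functional assay on SK-MEL-28 cells (Homo sapiens) for cytotoxicity, read by MTT assay; a lower number here means a stronger inhibitor, a higher number a weaker inhibitor:
- compound 1 `O=S(=O)(NCCCNc1nccc(-c2c(-c3cccc(F)c3)nc3sccn23)n1)c1ccc(Br)cc1`: 9400 nM
- compound 2 `O=S(=O)(NCCNc1nccc(-c2c(-c3cccc(F)c3)nc3sccn23)n1)c1ccc(C(F)(F)F)cc1`: 8450 nM

Compound 2 gives the lower of the two numbers in this assay, but its gap to compound 1 lies within the scatter, so the two cannot be told apart. Compound 3 `O=S(=O)(NCCNc1nccc(-c2c(-c3cccc(F)c3)nc3sccn23)n1)c1cccc(F)c1` differs from compound 2 in one place: 3-fluorophenyl in place of 4-(trifluoromethyl)phenyl on a sulfonyl sulfur. Among the measured compounds shown here, no measured pair in this set shows the effect of such a swap, so there is no basis for a step beyond the scatter in either direction. Compound 3 is expected to give about 9500 nM, within 3000 nM to 30000 nM. That expectation amounts to a step of a 1.1-fold higher number from compound 2 to compound 3 (0.05 log units; within the scatter).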

Compound 3, half-maximal inhibitory concentration: 18300 nM
Compound 3: middle estimate off by 1.9-fold (0.28 log units), on the low side, within the range that was stated.
By their numbers in this assay, from the lowest: compounds 2, 1 and 3 (each within the scatter of the next, the first and the last beyond it).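

In this assay, the swap of 4-(trifluoromethyl)phenyl for 3-fluorophenyl on a sulfonyl sulfur gives the first difference that clears the scatter: a 2.2-fold higher number from compound 2 to compound 3 (0.34 log units; beyond the scatter) is a modest step, so this position does affect the read-out. The other step, a 1.9-fold higher number from compound 1 to compound 3 (0.29 log units; within the scatter), leaves those two compounds indistinguishable. Nothing measured here explains the step.

As far as these compounds go, the swap changes both the substituent and where it sits, so the contribution of each remains unknown. A plain phenyl or an aminophenyl on the sulfonyl sulfur would be needed to separate them.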